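The source may hold more compounds than are shown below. What is called first, only, known or untested is meant among the compounds shown, and "the series" means these compounds.

Working notes on the series. Compound 1 `COc1ccc(C(=O)c2ccc(OC)c3c2OC(C)(C)C=C3)c(NC(=O)CBr)c1` carries a bromo group on a saturated chain carbon bound to a carbonyl carbon; in a functional assay on MCF7 cells (Homo sapiens) for antiproliferative activity, read by MTT assay, with a stated time of 48 h (a lower number here means a stronger inhibitor, a higher number a weaker inhibitor), compound 1 gives 2360 nM. Compound 2 `CNCC(=O)Nc1cc(OC)ccc1C(=O)c1ccc(OC)c2c1OC(C)(C)C=C2` differs from it by methylamino in place of bromo at that position and gives 820 nM, which is a 2.9-fold lower number from compound 1 to compound 2 (0.46 log units; beyond the scatter). Compound 3 `C=C(c1ccc2c(c1)C=CC(C)(C)O2)c1ccc(OC)cc1NC(=O)CO`, built on a different core, carries a hydroxy group on the same kind of chain carbon and gives 390 nM, the lowest number of the three measured compounds, with compound 2 nearest and compound 1 furthest.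

Compound 4 `C=C(c1ccc2c(c1)C=CC(C)(C)O2)c1ccc(OC)cc1NC(=O)CN` is the next member to be measured. The change from compound 3 is amino in place of hydroxy on a saturated chain carbon bound to a carbonyl carbon. Going by the values given here, the only measured step that bears on it is the one from compound 1 to compound 2, where a nitrogen-bearing group entered on the chain carbon in place of bromo and the number fell by a modest amount beyond the scatter. The present change swaps hydroxy for amino, both groups holding one donor and one acceptor, so the step is expected to be smaller, lying within or barely beyond the scatter, and if anything toward a lower number. For compound 4 the expected value is 250 nM, with a range from 100 nM to 700 nM, corresponding to an expected step of a 1.6-fold lower number from compound 3 to compound 4 (0.19 log units; within the scatter).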

Compound 4, half-maximal inhibitory concentration: 420 nM
Compound 4: middle estimate off by 1.7-fold (0.23 log units), on the low side; measured number inside the range.
By their numbers in this assay, from the lowest: compounds 3, 4 and 2 (each within the scatter of the next, the first and the last beyond it); then compound 1.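

In this assay, amino in place of hydroxy on a saturated chain carbon bound to a carbonyl carbon gives a 1.1-fold higher number from compound 3 to compound 4 (0.03 log units; within the scatter), so on this core the position does not tell the two groups apart. This qualifies the earlier step, a 2.9-fold lower number from compound 1 to compound 2 (0.46 log units; beyond the scatter), which was taken on the other core with bromo leaving: nitrogen entering on this chain carbon does not by itself bring a step beyond the scatter, so that earlier step cannot be credited to the nitrogen alone. Nothing at hand explains why amino and hydroxy read alike here.

The compounds shown leave open whether a larger or differently charged group on the same chain carbon, such as dimethylamino, a carboxylic acid or a longer aminoalkyl chain, would move the number beyond the scatter on this core. Going by these compounds alone, they also leave open how the two cores compare, since no pair carries the same chain group on both, and a methylamino or bromo group on the core of compound 3 would settle that comparison.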